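Fluoro on the benzyl ring: from compound 3 to compound 4

A few compounds are considered here, and "the series" means these few. Any claim that something is new, unique, unknown or untested is made for them only; others in the source may bear on it.

Measured so far:
compound 1 `O=C(/C=C/c1ccc(OCc2cn(Cc3ccccc3)nn2)cc1)c1ccc(Br)cc1` 22%
compound 2 `O=C(/C=C/c1ccc(OCc2cn(Cc3cccc(F)c3)nn2)cc1)c1ccc(Br)cc1` 34%
compound 3 `COc1ccc(C(=O)/C=C/c2ccc(OCc3cn(Cc4ccccc4)nn3)cc2)cc1` 51%

In a functional assay on HepG2 cells (Homo sapiens) for inhibition, read by MTT assay, with a stated time of 48 h, tested at 10 uM (on this read-out higher numbers stand for more inhibition of growth at the one concentration tested and lower numbers for less inhibition of growth), compound 3 stands highest of the three; compound 2 sits closest to it, compound 1 furthest, and both gaps are beyond the scatter. Compound 3 was reached from compound 1 by a number 29 percentage points higher from compound 1 to compound 3 (beyond the scatter), a methoxy in place of a bromo.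

Compound 4 `COc1ccc(C(=O)/C=C/c2ccc(OCc3cn(Cc4ccc(F)cc4)nn3)cc2)cc1` is not yet measured. It differs from compound 3 by fluoro in place of hydrogen on an aromatic carbon. For the measured compounds named here, the one measured step that bears on this change is a fluoro entering the same benzyl ring of the shared core: a number 12 percentage points higher from compound 1 to compound 2 (beyond the scatter). Going by the values given here, that step was modest and beyond the scatter, and nothing among the measured compounds speaks against a similar effect on the methoxy analogue. A comparable, modest upward step is therefore expected, a number 9 percentage points higher from compound 3 to compound 4 (within the scatter), though the position of the fluoro is not the same and the step may also fall within the scatter.

Compound 4 is estimated at 60% in this assay, with a range from 45% to 75%.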

Compound 4, percent growth inhibition at one concentration: 21%
Compound 4: the middle estimate sits 39 percentage points above what was measured; measured number below the stated range.
By their numbers in this assay, from the lowest: compounds 4 and 1 (each within the scatter of the next); then compound 2; then compound 3.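

In this assay, the benzyl to 4-fluorobenzyl change on the methoxy core gives a number 30 percentage points lower from compound 3 to compound 4 (beyond the scatter), so a fluoro on this ring does not carry a single direction of effect across the series. The benzyl ring is therefore a position where replacing one hydrogen can shift the read-out well beyond the scatter, and a step taken on one core does not transfer to the other. The direction reverses between the two pairs, which also differ in where the fluoro stands on the ring: the same change on two cores in this assay, a number 12 percentage points higher (beyond the scatter) from compound 1 to compound 2 and a number 30 percentage points lower (beyond the scatter) from compound 3 to compound 4, 42 percentage points apart, beyond the scatter of two such steps

From the compounds shown here alone, whether the reversal follows the core, the place of the fluoro or both stays open, since the two pairs differ in both respects. Also open, going by these compounds, is how this position responds to a group other than fluoro, such as a chloro, a trifluoromethyl or an amine on the benzyl ring.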